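The source may report more compounds than this note shows. Statements on the series, on what has been measured and on what is new or still open speak of the compounds shown alone.

Compound 2 `CC(Cc1ccccc1Cl)C1=NCCN1` is the reference point of this step. In an assay on PC-12 cells for displacement of a labelled ligand from Nischarin (Rattus norvegicus) (a higher number here means a weaker inhibitor, a lower number a stronger inhibitor), compound 2 gives 195 nM, the lowest of the two plain numbers available. Compound 3 `CC(Oc1ccccc1)C1=NCCN1` gives 309 nM in this assay, which sits within the usual scatter of the value of compound 2, so the two cannot be separated. Compound 1 `CC(Cc1ccccc1-c1cccnc1)C1=NCCN1` gives in this assay only a limit, > 1000 nM. Going by the values given here, the one measured step, an at least 5.1-fold lower number from compound 1 to compound 2 (0.70 log units; beyond the scatter), is therefore bounded by the limit of > 1000 nM in this assay, at which 1 of the 3 values shown sits, rather than by a number.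

Compound 4 `CC(Cc1ccccc1-c1cccc(O)c1)C1=NCCN1` has not yet been measured. It differs from compound 2 in one place: 3-hydroxyphenyl in place of chloro on an aromatic carbon. The step from compound 1 to compound 2 bears on this change, since it exchanged an aromatic six-membered ring at the same place for chloro and gave an at least 5.1-fold lower number from compound 1 to compound 2 (0.70 log units; beyond the scatter). Putting an aromatic ring back in place of the chloro is expected to move the number in the opposite direction, by a modest amount or more, the estimated step being a 6.2-fold higher number from compound 2 to compound 4 (0.79 log units; beyond the scatter). Whether 3-hydroxyphenyl behaves like pyridin-3-yl is not shown by any measured pair. For compound 4 in this assay the expected value is 1200 nM, with a range from 350 nM to 4000 nM, and a real chance that only a limit is reported.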

Compound 4, inhibition constant: > 1000 nM
Compound 4: no number, only a limit; the forecaster's own chance of this, stated with the estimate: 45%; the middle value lies beyond the limit too.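

Exchanging chloro for 3-hydroxyphenyl on this aromatic carbon gives an at least 5.1-fold higher number from compound 2 to compound 4 (0.70 log units; beyond the scatter), so in this assay a second kind of aromatic ring at this place goes the same way as the pyridin-3-yl of compound 1. Compound 4 yields only a limit, and the steps that would set it against compound 1 cannot be read, so the two aromatic groups cannot be ranked against each other. The comparison between them therefore rests on limits and not on numbers: the limit of > 1000 nM in this assay, at which 2 of the 4 values shown sit.

The compounds shown leave open how large the loss from compound 2, at 195 nM, really is for either aromatic group, and whether any ring at this place could keep that value. As far as these compounds go, it is also open whether a small group such as methyl or methoxy, a saturated ring such as cyclohexyl, or a phenyl ring carrying an amine or a carboxylic acid in place of the hydroxyl would behave like the chloro or like the two aromatic groups.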